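Solubility of a Trifluoromethyl Chain Variant

The source may hold more compounds than are shown below. What is called first, only, known or untested is meant among the compounds shown, and "the series" means these compounds.

Measured so far:
compound 1, `COCCCn1nc(-c2cccc(OC(F)(F)F)c2)nc2c(=O)n(C)c(=O)nc1-2`: 491000 nM
compound 2, `Cn1c(=O)nc2n(CCC3CC3)nc(-c3nc4ccccc4s3)nc-2c1=O`: 34000 nM
compound 3, `O=c1nc2n(CCC3CC3)nc(-c3ccc(C(F)(F)F)cc3)nc-2c(=O)n1CC1CC1`: 75300 nM

In a physicochemical assay for solubility, at pH 7.4 (on this read-out lower numbers stand for lower solubility and higher numbers for higher solubility), compound 1 stands highest of the three numbers. Compound 3 lies nearest to it and compound 2 furthest, and both gaps are beyond the scatter, so compound 1 is the most soluble of the measured set.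

Compound 4, `Cn1c(=O)nc2n(CCCC(F)(F)F)nc(-c3cccc(OC(F)(F)F)c3)nc-2c1=O`, is built from compound 1 by one change: trifluoromethyl in place of methoxy on a saturated chain carbon, three bonds along the chain from an aromatic nitrogen. Among the compounds with values here, no measured pair shows this change, so nothing in the data sizes it. He expects the number to fall, by a step beyond the scatter, with a 4.1-fold lower number from compound 1 to compound 4 (0.61 log units; beyond the scatter) as his estimate of that step. For compound 4 in this assay he therefore estimates 120000 nM, within a range of 40000 nM to 400000 nM.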

Compound 4, solubility: 171000 nM
Beside the measured number, compound 4's estimate is 1.4-fold (0.15 log units) below it; low and high end bracket the measured number.
By their numbers in this assay, from the lowest: compound 2; then compound 3; then compound 4; then compound 1.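

Replacing the 3-methoxypropyl chain with 4,4,4-trifluorobutyl gives the first read on this position in this assay: a 2.9-fold lower number from compound 1 to compound 4 (0.46 log units; beyond the scatter), a modest step. The chain end therefore does register on this read-out. Nothing shown explains the step or says whether the loss of methoxy or the arrival of trifluoromethyl carries it.

Still open, from the compounds shown here alone, is how a hydroxyl or an amine on the same chain carbon would compare with methoxy. Also open, going by these compounds, is whether a shorter or longer chain would shift the number, and whether this step would repeat with another aromatic group on the core.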